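Diaryl ether thiosemicarbazones: lipophilicity and the chloro-to-hydrogen step

The compounds below may be only part of what the source reports. "The series", "measured", "known", "first", "only" and "open" are said of these compounds alone.

Compound 1 `S=C(N/N=C/c1ccc(Oc2ccc3ccccc3c2)cc1)Nc1ccc(Cl)cc1`, compound 2 `S=C(N/N=C/c1ccc(Oc2ccc3ccccc3c2)cc1)Nc1ccccc1` and compound 3 `S=C(N/N=C/c1ccc(Oc2ccccc2)cc1)Nc1ccc(Cl)cc1` have been measured in a physicochemical assay for lipophilicity, in phosphate buffer, measured as octanol-water partition, with a stated time of 24 h; on this read-out higher numbers stand for higher lipophilicity and lower numbers for lower lipophilicity; compound 4 `S=C(N/N=C/c1ccc(Oc2ccccc2)cc1)Nc1ccccc1` has not. Compound 1 gives 6.96, compound 2 gives 6.07 and compound 3 gives 5.64 in this assay. The change hydrogen in place of chloro on an aromatic carbon made a step of a number 0.89 log units lower from compound 1 to compound 2 (beyond the scatter). The two cores differ by phenyl in place of naphthalen-2-yl on an oxygen on an aromatic ring, which made a step of a number 1.32 log units lower from compound 1 to compound 3 (beyond the scatter). Compound 3 stands lowest of the three measured numbers. Compound 4 differs from compound 3 by hydrogen in place of chloro on an aromatic carbon, the same change as from compound 1 to compound 2, made on the core of compound 3 rather than that of compound 1; it occurs twice among these four compounds. Going by the values given here, for compound 4 the step of a number 0.89 log units lower from compound 3 to compound 4 (beyond the scatter) is expected to be of the same size as the earlier one, because a number 0.89 log units lower from compound 1 to compound 2 (beyond the scatter) is the only measured instance of this change here and nothing in the data suggests the core alters it. Compound 4 is therefore estimated at 4.75, with a range of 4.3 to 5.2.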

Compound 4, partition coefficient: 4.9
Compound 4: middle estimate off by 0.15 log units, on the low side, and the stated range covers the measured number.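

In this assay, the change from chloro to hydrogen on an aromatic carbon gives a number 0.74 log units lower from compound 3 to compound 4 (beyond the scatter), set against a number 0.89 log units lower from compound 1 to compound 2 (beyond the scatter) on the naphthalen-2-yl side of the pair. Both steps run in the same direction and both rank as modest, so within these four compounds the change carries from the core of compound 1 to the core of compound 3 with its direction and rough size kept. This rests on two pairs and two cores only, which gives no general rule for the series, and nothing here bears on why the step behaves this way.

From the compounds shown here alone, whether the step would hold on a third core, for instance with another aryl group in place of phenyl on the ether oxygen, remains open. Also open, going by these compounds, is how fluoro, methoxy, a dimethylamino group or a carboxylic acid at the place of the chloro would compare with chloro and hydrogen in this assay on either core.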